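This account rests on a few compounds, and the source may have more. Where it says the series, first, only, none or still open, it means among the compounds named here.

This series shares the core of compound 1 `CCCn1c(=O)[nH]c2nc(-c3ccc(S(=O)(=O)N(C)C)cc3)[nH]c2c1=O`, which in an assay on CHO cells for displacement of a labelled ligand from adenosine receptor A3 (Homo sapiens), read by scintillation counting, with a stated time of 45 min, in the presence of a further agent that is not named here (on this read-out higher numbers stand for weaker inhibition and lower numbers for stronger inhibition), gives 1220 nM. Compound 2 `CCCn1c(=O)[nH]c2nc(-c3ccc(S(=O)(=O)N4CCN(c5ccccc5Br)CC4)cc3)[nH]c2c1=O` reaches only the limit of the assay, > 1000 nM, not a number. Compound 3 `CCCn1c(=O)c2[nH]c(-c3ccc(S(=O)(=O)N4CCN(c5ccc(Cl)cc5)CC4)cc3)nc2n(C)c1=O` likewise returns only the limit, > 1000 nM. The picture is shaped by the limit of > 1000 nM in this assay, at which 2 of the 3 values shown sit, and compound 2 stands there, without a number of its own. Compound 4 `CCCn1c(=O)[nH]c2nc(-c3ccc(S(=O)(=O)N4CCN(c5ccccc5Cl)CC4)cc3)[nH]c2c1=O` differs from compound 2 by chloro in place of bromo on an aromatic carbon, bromo leaving and chloro entering on an aromatic carbon of a six-membered aromatic ring of carbon only. Among the measured compounds shown here, with no measured step between compounds to draw on, the expected step from compound 2 to compound 4, a step that the limit leaves unreadable from compound 2 to compound 4, is none beyond the scatter. Compound 4 is therefore estimated at 1500 nM, within 700 nM to 4000 nM.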

Compound 4, inhibition constant: > 1000 nM
Compound 4: no number, only a limit; the forecaster's own chance of this, stated with the estimate: 70%; the middle value does not contradict the limit.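

Compound 2 and compound 4 each give only a limit, not a number, so no step can be read between them: the limit of > 1000 nM in this assay, at which 3 of the 4 values shown sit. The compounds shown leave open how strongly either inhibits in this assay, and whether chloro in place of bromo changes that.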